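This account rests on a few compounds, and the source may have more. Where it says the series, first, only, none or still open, it means among the compounds named here.

Compound 1 `CN(C)CCn1cc(S(=O)(=O)c2ccccc2)c2cccnc21` is examined in a functional assay on HeLa cells for agonist activity at 5-hydroxytryptamine receptor 6 (Homo sapiens), read by immunoassay; on this read-out lower numbers stand for smaller maximal responses and higher numbers for larger maximal responses; in this assay compound 1 gives 94%. Among the compounds with values here, its only measured neighbour is compound 2 `Cc1c(S(=O)(=O)c2ccccc2)c2cccnc2n1CCN(C)C`, which in this assay gives 100%; between the two lies a number 6 percentage points higher from compound 1 to compound 2 (within the scatter), brought about by methyl in place of hydrogen on an aromatic carbon. A third member of the series, compound 3 `O=S(=O)(c1cccc(F)c1)c1cn(CCN2CCCC2)c2ncccc12`, gives "not determined" (no result reported) in this assay, so compound 1 stands against one number only, and that one within the scatter of its own.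

The step to compound 4 `CN(C)CCn1cc(S(=O)(=O)c2ccc(Cl)s2)c2cccnc21` is of a different kind: 5-chlorothiophen-2-yl in place of phenyl on a sulfonyl sulfur. Within the data shown here, none of the measured compounds varies the group on the sulfonyl sulfur, so no measured step speaks directly to this change. Among the measured compounds shown here, what the series shows is that the one change tried so far, a number 6 percentage points higher from compound 1 to compound 2 (within the scatter), left the maximal response essentially unchanged, and that both measured compounds give near-full responses in this assay. On that basis the step of a number 2 percentage points lower from compound 1 to compound 4 (within the scatter) is expected to stay within the scatter. Compound 4 is therefore estimated to give 92% in this assay, with a range from 78% to 104%.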

Compound 4, largest response reached (Emax), in percent of the reference or control that the assay uses: 93%
Compound 4: middle estimate off by 1 percentage points, on the low side; the measured number falls inside the stated range.
By their numbers in this assay, from the lowest: compounds 4, 1 and 2 (each within the scatter of the next).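

In this assay, within the data shown here, the exchange on the sulfonyl sulfur gives the first reading at this position, with a number 1 percentage points lower from compound 1 to compound 4 (within the scatter). One six-membered aromatic ring of carbon only gives way to one five-membered aromatic ring with 1 hetero atom and a chlorine on it, yet this pair shows no difference in maximal response beyond the scatter, so this position accepts this particular exchange on this read-out. No measurement shown explains why the two groups give responses within the scatter of each other.

Among these compounds, whether the same holds for a saturated ring such as cyclohexyl, for a larger aromatic group such as naphthyl, or for a small alkyl group such as methyl on the sulfonyl sulfur remains open, since the single pair speaks only for 5-chlorothiophen-2-yl against phenyl. Also open, going by these compounds, is whether 5-chlorothiophen-2-yl on the sulfonyl sulfur would give a similar maximal response when combined with the methyl on an aromatic carbon of compound 2, and how the concentration needed for the response compares across these compounds.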